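Hydrazide in place of acylsulfonamide: expected solubility

This account rests on a few compounds, and the source may have more. Where it says the series, first, only, none or still open, it means among the compounds named here.

Compound 3 `CS(=O)(=O)NC(=O)c1ccc(-c2cc(-c3ccc(C#N)cc3)nc(-c3ccco3)c2)cc1` holds the highest number of the three compounds measured in a physicochemical assay for solubility, at pH 6; a higher number here means a more soluble compound, a lower number a less soluble compound: compound 3 gives 32000 nM. Its nearest neighbour is compound 1 `N#Cc1ccc(-c2cc(-c3ccc(C(N)=O)cc3)cc(-c3ccco3)n2)cc1`, which in this assay gives 10000 nM, the gap being a 3.2-fold higher number from compound 1 to compound 3 (0.51 log units; beyond the scatter). Compound 2 `N#Cc1ccc(-c2cc(-c3ccccc3)cc(-c3ccco3)n2)cc1` lies furthest away, giving 2000 nM, reached through a 16-fold higher number from compound 2 to compound 3 (1.20 log units; beyond the scatter); compound 1 and compound 2 are themselves separated by a 5.0-fold lower number from compound 1 to compound 2 (0.70 log units; beyond the scatter).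

Compound 4 `N#Cc1ccc(-c2cc(-c3ccc(C(=O)NN)cc3)cc(-c3ccco3)n2)cc1` differs from compound 3 in one place: amino in place of methylsulfonyl on an amide-type nitrogen. The change thus removes the methylsulfonyl that distinguishes compound 3 from compound 1 and puts an amino group in its stead. Going by the values given here, the one measured step that bears on it directly is a 3.2-fold higher number from compound 1 to compound 3 (0.51 log units; beyond the scatter), a modest rise, which read backwards points to a modest fall from compound 3. Among the compounds with values here, for the remaining part of the change, amino in place of hydrogen on an amide-type nitrogen, the data hold no measured step, so nothing beyond the scatter can be claimed for it in either direction. The expected step is therefore a 2.7-fold lower number from compound 3 to compound 4 (0.43 log units; beyond the scatter), a modest fall. Compound 4 is expected to give 12000 nM in this assay, within a range from 5000 nM to 30000 nM.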

Compound 4, solubility: 500000 nM
Compound 4: the middle estimate sits 42-fold (1.62 log units) below what was measured, outside the stated range (above it).
By their numbers in this assay, from the lowest: compound 2; then compound 1; then compound 3; then compound 4.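

On the amide-type nitrogen, whose other neighbour is the carbonyl carbon, amino in place of hydrogen gives a far larger change in this assay than the earlier compounds had shown there: the step is a 50-fold higher number from compound 1 to compound 4 (1.70 log units; beyond the scatter), against a 3.2-fold higher number from compound 1 to compound 3 (0.51 log units; beyond the scatter) for methylsulfonyl on the same nitrogen. Methylsulfonyl is therefore not what gives this position its highest number, since amino in its place gives a 16-fold higher number from compound 3 to compound 4 (1.19 log units; beyond the scatter), and the whole aminocarbamoyl group, in place of hydrogen on the aromatic carbon, gives a 250-fold higher number from compound 2 to compound 4 (2.40 log units; beyond the scatter), a larger step than a 16-fold higher number from compound 2 to compound 3 (1.20 log units; beyond the scatter) for (methylsulfonyl)carbamoyl. No measurement among those available accounts for the size of this rise.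

The compounds shown leave open whether the rise belongs to amino alone or would carry over to other groups on this nitrogen, such as hydroxyl, methylamino or dimethylamino. They also leave open how a carboxylic acid on the same aromatic carbon would compare with aminocarbamoyl, and whether the high number of compound 4 would hold with another group in place of the furan or the nitrile on the shared core.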